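This account rests on a few compounds, and the source may have more. Where it says the series, first, only, none or still open, it means among the compounds named here.

Measured so far in a physicochemical assay for solubility, measured as thermodynamic solubility, with a stated time of 24 h, at pH 6.8; on this read-out lower numbers stand for lower solubility and higher numbers for higher solubility:
compound 1 `Cc1cc(C)c2cc(C(=O)NC3CCCCC3)[nH]c2c1`: < 4000 nM, a limit of the assay
compound 2 `Cc1cc(C)c2cc(C(=O)NC(C)C)[nH]c2c1`: 20000 nM
compound 3 `Cc1cc(C)c2cc(C(=O)NC3CCCCCC3)[nH]c2c1`: < 4000 nM, a limit of the assay

Compound 3 sits at the limit of < 4000 nM in this assay, at which 2 of the 3 values shown sit, so its reading in this assay is a limit and not a number. Among the measured steps, an at least 5.0-fold lower number from compound 2 to compound 3 (0.69 log units; beyond the scatter) is beyond the scatter, as is an at least 5.0-fold higher number from compound 1 to compound 2 (0.69 log units; beyond the scatter), whereas a step that the two limits leave unreadable from compound 1 to compound 3 cannot be sized since both ends are limits. Within this small set the two carbocyclic amides both sit at the limit and only the isopropyl amide gives a readable number.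

Compound 4 `Cc1cc(C)c2cc(C(=O)NC3CCCCC3O)[nH]c2c1` differs from compound 3 by 2-hydroxycyclohexyl in place of cycloheptyl on an amide-type nitrogen. For the measured compounds named here, no measured step exchanges a carbocycle for a hydroxylated one, so the steps above give no direct precedent; they show only that the ring amides of this core have so far stayed at the limit. Because compound 3 sits at the limit of < 4000 nM in this assay, at which 2 of the 3 values shown sit, any rise for compound 4 would be readable while any fall would not. The step is expected to be an increase, an at least 2.0-fold higher number from compound 3 to compound 4 (0.30 log units; that floor lies within the scatter), with compound 4 estimated at 8000 nM in this assay, in a range from 2000 nM to 40000 nM.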

Compound 4, solubility: 56000 nM
Compound 4: the middle estimate sits 7.0-fold (0.85 log units) below what was measured; measured number outside the range, above it.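

In this assay, for the compounds shown here, hydroxy in place of hydrogen on a saturated ring carbon is the first single change here that takes a ring amide off the limit, with an at least 14-fold higher number from compound 1 to compound 4 (1.14 log units; beyond the scatter), and the exchange for cycloheptyl on the amide-type nitrogen reads alike, with an at least 14-fold higher number from compound 3 to compound 4 (1.14 log units; beyond the scatter). Going by these compounds alone, both steps are floors and not sizes, as each starts from a limit: the limit of < 4000 nM in this assay, at which 2 of the 4 values shown sit A ring on this nitrogen is also no bar to a readable number, since 2-hydroxycyclohexyl stands past isopropyl, with a 2.8-fold higher number from compound 2 to compound 4 (0.45 log units; beyond the scatter), which the earlier compounds, where only the isopropyl amide gave a number, could not show.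

Going by these compounds, whether an amino group or a methoxy group on the same saturated ring carbon would give a like step stays open, as does the outcome of hydroxy on the cycloheptyl ring or on the isopropyl group. On these data alone, the order of compound 1 and compound 3 also stays unreadable, with both at the limit, so the effect of ring size without the hydroxy remains unknown.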